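The compounds below may be only part of what the source reports. "The series", "measured", "known", "first", "only" and "open" are said of these compounds alone.

Working notes on the series. Compound 3 is `COc1ccc(CNC(=O)c2nn(-c3ccc(F)cc3)c(OC[C@@H](O)C[C@@H](O)CC(=O)O)c2C(C)C)cc1`; in a functional assay on L6 cells (Rattus norvegicus) for inhibition (a higher number here means a weaker inhibitor, a lower number a stronger inhibitor), compound 3 gives "not determined" (no result reported), so it has no number to stand on. Its neighbours with the ethylene-linked side chain do: compound 1 `CC(C)c1c(C(=O)N(C)Cc2ccccc2)nn(-c2ccc(F)cc2)c1CC[C@@H](O)C[C@@H](O)CC(=O)O` gives 2870 nM in this assay, and compound 2 `CC(C)c1c(C(=O)N(C)Cc2cccc(F)c2)nn(-c2ccc(F)cc2)c1CC[C@@H](O)C[C@@H](O)CC(=O)O` gives 1900 nM. Within the data shown here, the one counted step among them, a 1.5-fold lower number from compound 1 to compound 2 (0.18 log units; within the scatter), is a fluoro in place of hydrogen on an aromatic carbon and moves nothing beyond the scatter. The step to compound 4 `Cc1cccc(CN(C)C(=O)c2nn(-c3ccc(F)cc3)c(OC[C@@H](O)C[C@@H](O)CC(=O)O)c2C(C)C)c1` is different: methyl(3-methylbenzyl)amino in place of (4-methoxybenzyl)amino on a carbonyl carbon. Among the measured compounds shown here, no measured step covers this exchange, and compound 3 itself is without a number; only the level of compound 1 and compound 2 can be read across. For compound 4 the expectation in this assay is therefore a value near that level, estimated at 2500 nM, with a wide range from 600 nM to 10000 nM.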

Compound 4, half-maximal inhibitory concentration: 18500 nM
Estimate against measurement, compound 4: 7.4-fold (0.87 log units) below; the whole stated range lies below it.
By their numbers in this assay, from the lowest: compounds 2 and 1 (each within the scatter of the next); then compound 4.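

No new step can be read: compound 3 carries no number in this assay, so compound 4 has no measured partner. What the exchange to methyl(3-methylbenzyl)amino does on its own stays open, and nothing shown bears on a cause for the value of compound 4.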